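The source may hold more compounds than are shown below. What is called first, only, known or untested is meant among the compounds shown, and "the series" means these compounds.

Measured compounds:
- compound 2, `C=C(CC)C(=O)c1ccc(OCC(=O)NCO[N+](=O)[O-])c(Cl)c1Cl`: in a functional assay on CLL cells (Homo sapiens) for cytotoxicity, read by MTT assay, with a stated time of 48 h (a higher number here means that more compound is needed for the effect, a lower number that less compound is needed), compound 2 gives 4100 nM
- compound 3, `C=C(CC)C(=O)c1ccc(OCC(=O)NCC2CCC(C(=O)O)CC2)c(Cl)c1Cl`: in this assay compound 3 gives 8000 nM
- compound 1, `C=C(CC)C(=O)c1ccc(OCC(=O)Nc2ccc(C(=O)O)c(O)c2)c(Cl)c1Cl`: in this assay compound 1 gives only a limit of the assay, > 25000 nM

Compound 2 holds the lowest of the two numbers in this assay; its nearest neighbour is compound 3, and the step of a 2.0-fold higher number from compound 2 to compound 3 (0.29 log units; within the scatter) stays within the scatter. Compound 1 reaches only the limit of > 25000 nM in this assay, at which 1 of the 3 values shown sits, and cannot be ranked against the other two.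

The unmeasured compound 4, `C=C(CC)C(=O)c1ccc(OCC(=O)Nc2ccc(C(C)=O)cc2)c(Cl)c1Cl`, differs from compound 2 in one place: 4-acetylphenyl in place of (nitrooxy)methyl on an amide-type nitrogen. Within the data shown here, the only measured step on the same nitrogen, a 2.0-fold higher number from compound 2 to compound 3 (0.29 log units; within the scatter), exchanged the (nitrooxy)methyl group for a saturated ring without moving the number beyond the scatter. Among the measured compounds shown here, compound 1, the one other case with an aromatic ring on that nitrogen, reached only the limit, and no step is given between it and compound 2. On this thin basis a modest rise in the number is expected in this assay, with wide uncertainty: the step of a 1.7-fold higher number from compound 2 to compound 4 (0.23 log units; within the scatter) is the estimate. Compound 4 is thus expected to give about 7000 nM, plausibly between 1500 nM and 25000 nM.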

Compound 4, half-maximal effective concentration: 3900 nM
Compound 4: the middle estimate sits 1.8-fold (0.25 log units) above what was measured; low and high end bracket the measured number.
By their numbers in this assay, from the lowest: compounds 4, 2 and 3 (each within the scatter of the next, the first and the last beyond it). At a limit, above all of these: compound 1.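

The step shows that the amide-type nitrogen accepts a far larger group than the earlier compounds had shown, and one with a six-membered aromatic ring: 4-acetylphenyl, with its 9 heavy atoms, enters for the 5 of (nitrooxy)methyl, and this assay records a 1.1-fold lower number from compound 2 to compound 4 (0.02 log units; within the scatter). The nitrooxy group is therefore not needed for a number in this range, since compound 4 has none. Compound 1 also carries an aromatic ring on that nitrogen, yet it gives only a limit: the limit of > 25000 nM in this assay, at which 1 of the 4 values shown sits. An aromatic ring there thus does not by itself lead to that limit.

From the compounds shown here alone, it stays open whether an amine or a carboxylic acid in place of the acetyl would keep the number in this range. Going by these compounds, it also stays open how a longer chain on the same nitrogen would read.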